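The compounds below may be only part of what the source reports. "The series", "measured", "known", "first", "only" and "open" are said of these compounds alone.

Measured in an ADME assay on CEM-SS cells (Homo sapiens) for cytotoxicity, read by XTT assay, with a stated time of 6 days; a lower number here means that less compound is tolerated, a higher number that more compound is tolerated:
Compound 1 `CCCC(=O)OCSc1ccccc1C(=O)N[C@H]1CCC[C@H]1C(N)=O`: 89.9 uM; 84.8 uM (2 entries)
Compound 2 `CCCC(=O)OCSc1ccccc1C(=O)N(C)CC(N)=O`: 55.3 uM

The repeat measurements of compound 1 lie close together, as this record shows: the several entries of compound 1 in this assay, 89.9 uM; 84.8 uM (2 entries). Compound 2 has only one numerical result, 55.3 uM, and a further entry for it gives no single number. That result lies within the usual scatter of the values for compound 1, so the two compounds cannot be ranked in this assay.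

Compound 3 `C#CCNC(=O)CNC(=O)c1ccccc1SCOC(=O)CCC` is the next compound to be tested. It carries ((propargylcarbamoyl)methyl)amino in place of the (carbamoylmethyl)(methyl)amino of compound 2, on a carbonyl carbon whose other neighbour is an aromatic carbon: ((propargylcarbamoyl)methyl)amino in place of (carbamoylmethyl)(methyl)amino on a carbonyl carbon. Going by the values given here, no measured pair shows this change directly, so the expectation rests on a narrow base. Compound 1 at 89.9 uM; 84.8 uM (2 entries) and compound 2 at 55.3 uM stay within the scatter of each other, so no clear move in either direction is expected in this assay. The estimated step of a 1.1-fold higher number from compound 2 to compound 3 (0.04 log units; within the scatter) is expected to remain within the scatter. Compound 3 is expected at 60 uM, with an estimated range of 28 uM to 125 uM.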

Compound 3, half-maximal toxic concentration: 95.4 uM
The estimate for compound 3 lay 1.6-fold (0.20 log units) below the measured number; the range from low to high includes it.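

In this assay, going by these compounds alone, changing the group on a carbonyl carbon whose other neighbour is an aromatic carbon gives the first step that can be read directly: a 1.7-fold higher number from compound 2 to compound 3 (0.24 log units; within the scatter). The entering group has more heavy atoms, a triple bond and 2 hydrogen-bond donors against 1, yet compound 2 and compound 3 remain within the scatter of each other, so this exchange at this position gives no measurable separation in the read-out. The repeat entries show how closely a compound's result can recur in this test: the several entries of compound 1 in this assay, 89.9 uM; 84.8 uM (2 entries).

The exchange combines two differences, the propargyl group on the terminal amide and the loss of the methyl group from the amide nitrogen, and the compounds shown cannot separate their contributions. As far as these compounds go, whether an amine, a carboxylic acid or a longer chain in place of ((propargylcarbamoyl)methyl)amino on the same carbonyl carbon would give a value beyond the scatter remains open.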